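The source may hold more compounds than are shown below. What is called first, only, known or untested is meant among the compounds shown, and "the series" means these compounds.

Of the compounds shown here, three have been measured in an ADME assay on MT4 cells (Homo sapiens) for cytotoxicity, read by MTT assay, with a stated time of 4 days; on this read-out lower numbers stand for higher toxicity in this test and higher numbers for lower toxicity in this test.

Compound 1 `COc1ccccc1Oc1nc(Nc2ccc(C#N)cc2)nc2ccccc12` gives 150000 nM.
Compound 2 `N#Cc1ccc(Nc2nc(Oc3ccc(F)cc3)c3ccccc3n2)cc1` reaches only the limit of this assay, > 351000 nM.
Compound 3 `Cc1cc(C#N)cc(C)c1Oc1nc(Nc2ccc(C#N)cc2)nc2ccccc12` gives 203000 nM.

Among the two plain numbers, compound 3 and compound 1 sit within the usual scatter of each other, as a 1.4-fold higher number from compound 1 to compound 3 (0.13 log units; within the scatter) shows, while compound 2 contributes only a limit, (the limit of > 351000 nM in this assay, at which 1 of the 3 values shown sits). Compound 4 `N#Cc1ccc(Nc2nc(Oc3c(Br)cc(Br)cc3Br)c3ccccc3n2)cc1` differs from compound 3 in one place: 2,4,6-tribromophenyl in place of 4-cyano-2,6-dimethylphenyl on an oxygen on an aromatic ring. Every measured step here swaps the ring on that same oxygen: a 1.4-fold higher number from compound 1 to compound 3 (0.13 log units; within the scatter) and an at least 1.7-fold lower number from compound 2 to compound 3 (0.23 log units; that floor lies within the scatter) stay within the scatter, and only an at least 2.3-fold higher number from compound 1 to compound 2 (0.36 log units; beyond the scatter) goes modestly beyond it, toward a limit. The step of a 1.0-fold lower number from compound 3 to compound 4 (0.01 log units; within the scatter) is therefore expected to stay within the scatter. Compound 4 is estimated at 200000 nM, with a likely range from 80000 nM to 450000 nM.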

Compound 4, half-maximal cytotoxic concentration: 58000 nM
Compound 4: the middle estimate sits 3.4-fold (0.54 log units) above what was measured; the measured number lies below the stated range.
By their numbers in this assay, from the lowest: compound 4; then compounds 1 and 3 (each within the scatter of the next). At a limit, above all of these: compound 2.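

In this assay, among these compounds, changing the ring on this oxygen can clearly lower the number, which no earlier step showed: 2,4,6-tribromophenyl gives a 3.5-fold lower number from compound 3 to compound 4 (0.54 log units; beyond the scatter) and a 2.6-fold lower number from compound 1 to compound 4 (0.41 log units; beyond the scatter). The largest step is an at least 6.0-fold lower number from compound 2 to compound 4 (0.78 log units; beyond the scatter). Compound 2 stands at a limit, so the size of that step is only a floor: the limit of > 351000 nM in this assay, at which 1 of the 4 values shown sits.

Which of the three bromines matter, singly or together, stays open. So does whether 2,4,6-trichlorophenyl, or a phenyl ring carrying an amine or a carboxylic acid, would move the number the same way.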